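The source may report more compounds than this note shows. Statements on the series, on what has been measured and on what is new or still open speak of the compounds shown alone.

In a functional assay on DU-145 cells (Homo sapiens) for inhibition, read by trypan blue exclusion, with a stated time of 72 h (a lower number here means a stronger inhibitor, a higher number a weaker inhibitor), compound 1 (`Cn1c(=O)c(S(=O)(=O)c2ccc(Cl)cc2)cc2cnc(Nc3ccc4[nH]ccc4c3)nc21`) gives 250 nM, and compound 2 (`Cc1ccc(S(=O)(=O)c2cc3cnc(Nc4ccc5cc[nH]c5c4)nc3n(C)c2=O)cc1`) gives 15000 nM. Compound 2 therefore holds the higher of the two numbers, and its gap to compound 1 lies well beyond the scatter of repeated measurements. These two compounds are not joined by a single change, so neither number shows on its own what any one group contributes.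

Compound 3 (`Cc1ccc(S(=O)(=O)c2cc3cnc(Nc4ccc5[nH]ccc5c4)nc3n(C)c2=O)cc1`) stands one change from compound 2: 1H-indol-5-yl in place of 1H-indol-6-yl on a nitrogen on an aromatic ring. The same atoms are joined differently, with 1H-indol-5-yl in place of 1H-indol-6-yl on a nitrogen on an aromatic ring. Compound 1 also carries 1H-indol-5-yl on such a nitrogen and gives 250 nM, so a large move toward a stronger inhibitor, beyond the scatter, is expected in this assay. On these data alone, how much of the gap goes with this group remains unknown, and the expectation is correspondingly loose. The expected step is a 38-fold lower number from compound 2 to compound 3 (1.57 log units; beyond the scatter). For compound 3 the estimated value is 400 nM, with an expected range of 100 nM to 2500 nM.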

Compound 3, half-maximal inhibitory concentration: 750 nM
The estimate for compound 3 lay 1.9-fold (0.27 log units) below the measured number; low and high end bracket the measured number.
By their numbers in this assay, from the lowest: compound 1; then compound 3; then compound 2.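

The step of a 20-fold lower number from compound 2 to compound 3 (1.30 log units; beyond the scatter) in this assay goes with nothing more than moving the attachment from 1H-indol-6-yl to 1H-indol-5-yl on a nitrogen on an aromatic ring, so with the atoms unchanged, the point at which the indole joins that nitrogen is shown on its own to matter a great deal in this pair. The second single change, methyl in place of chloro on an aromatic carbon, accounts for a 3.0-fold higher number from compound 1 to compound 3 (0.48 log units; beyond the scatter) and shows that this other place also moves the number beyond the scatter, though by a modest step in this one pair. Nothing given here bears on why either change has the effect it does.

On these data alone, whether the step between the two indole attachments would keep its size with chloro rather than methyl on that aromatic carbon remains open, so it cannot be said whether the two steps simply add. Also open, as far as these compounds go, is how a methoxy group on that carbon, or 1H-indol-4-yl on the nitrogen, would compare with the groups seen so far.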